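Replacing a Halogenated Ring with a Hydroxy-Methoxy Ring

The source may hold more compounds than are shown below. What is called first, only, known or untested is meant among the compounds shown, and "the series" means these compounds.

Measured compounds:
Compound 1, `COc1ccc(CNc2ncnc3c2ncn3[C@@H]2O[C@H](CO)[C@@H](O)[C@H]2O)c(OC)c1`: in a functional assay on B16 cells (Mus musculus) for antiproliferative activity, with a stated time of 72 h (on this read-out lower numbers stand for stronger inhibition and higher numbers for weaker inhibition), compound 1 gives "not determined" (no result reported).
Compound 2, `OC[C@H]1O[C@@H](n2cnc3c(NCc4ccc(F)cc4Cl)ncnc32)[C@H](O)[C@@H]1O`: compound 2 gives > 166000 nM, which is a limit of the assay and not a number.
Compound 3, `OC[C@H]1O[C@@H](n2cnc3c(NCc4ccc(F)c(Cl)c4)ncnc32)[C@H](O)[C@@H]1O`: compound 3 gives 167000 nM.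

Within the data shown here, compound 3 therefore holds the only plain number among the three entries in this assay; beside it stand one limit and one entry without a result. Compound 4 is `COc1cccc(CNc2ncnc3c2ncn3[C@@H]2O[C@H](CO)[C@@H](O)[C@H]2O)c1O`, and it differs from compound 3 in one place: 2-hydroxy-3-methoxyphenyl in place of 3-chloro-4-fluorophenyl on a saturated chain carbon bound to a nitrogen on an aromatic ring.

Among the measured compounds shown here, only one measured step exists, a step that the limit leaves unreadable from compound 2 to compound 3, and it compares two halogen-bearing rings with each other; it says nothing about swapping in a ring that carries oxygen. The boundary the limit of > 166000 nM in this assay, at which 1 of the 3 values shown sits, marks where results in this assay stop being numbers, and compound 3 sits right at that edge. For the measured compounds named here, no measured step points upward or downward for the change to compound 4.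

Compound 4 is expected to stay close to compound 3, with the step of a 1.0-fold lower number from compound 3 to compound 4 (0.02 log units; within the scatter) estimated to lie within the usual scatter, and a fair chance that only a limit is reported. The estimate for compound 4 is 160000 nM, expected between 60000 nM and 400000 nM.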

Compound 4, half-maximal inhibitory concentration: > 166000 nM
Compound 4 was reported as a limit (the forecaster's own chance of this, stated with the estimate: 50%); middle value at least 1.0-fold (0.01 log units) from the limit.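

The result for compound 4 is a limit of the assay and not a number, and neither the step from compound 3 to compound 4 nor the step from compound 2 to compound 4 can be read. The compounds shown leave open whether 2-hydroxy-3-methoxyphenyl in place of 3-chloro-4-fluorophenyl changes the result at all in this assay.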